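From ethyl to cyclopropyl on the amide nitrogen

This account rests on a few compounds, and the source may have more. Where it says the series, first, only, none or still open, it means among the compounds named here.

Measured compounds:
Compound 1, `CNC(=O)c1cc(Oc2cccc(NC(=S)Nc3cccc(C(F)(F)F)c3)c2)ccn1`: 25300 nM
Compound 2, `CCNC(=O)c1cc(Oc2cccc(NC(=S)Nc3cccc(C(F)(F)F)c3)c2)ccn1`: 19400 nM

In a functional assay on HCT-116 cells (Homo sapiens) for cytotoxicity, read by MTT assay, with a stated time of 48 h (a higher number here means a weaker inhibitor, a lower number a stronger inhibitor), compound 2 gives 19400 nM, the lowest of the two numbers recorded; its nearest neighbour is compound 1, and the step of a 1.3-fold lower number from compound 1 to compound 2 (0.12 log units; within the scatter) keeps the two within the usual scatter of such measurements, so no order between them can be claimed.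

Compound 3 is `O=C(NC1CC1)c1cc(Oc2cccc(NC(=S)Nc3cccc(C(F)(F)F)c3)c2)ccn1`. It differs from compound 2 by cyclopropyl in place of ethyl on an amide-type nitrogen. For the measured compounds named here, the only measured step that bears on this position is the change from hydrogen to methyl on the saturated chain carbon bound to the amide-type nitrogen, a 1.3-fold lower number from compound 1 to compound 2 (0.12 log units; within the scatter), which did not move the number beyond the scatter. Nothing else in the recorded data touches this part of the shared core. The step from compound 2 to compound 3 is therefore expected to be small in this assay, with no direction beyond the scatter that can be read from the existing pair; the estimated step is a 1.3-fold lower number from compound 2 to compound 3 (0.11 log units; within the scatter).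

Compound 3 is estimated at 15000 nM, with a range from 6000 nM to 40000 nM.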

Compound 3, half-maximal inhibitory concentration: 20200 nM
Compound 3: the middle estimate sits 1.3-fold (0.13 log units) below what was measured, and the stated range covers the measured number.
By their numbers in this assay, from the lowest: compounds 2, 3 and 1 (each within the scatter of the next).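

In this assay, the step to a ring on the amide-type nitrogen amounts to a 1.0-fold higher number from compound 2 to compound 3 (0.02 log units; within the scatter), and measured against the smallest substituent in the set it amounts to a 1.3-fold lower number from compound 1 to compound 3 (0.10 log units; within the scatter). For the compounds shown here, until now this position had been probed only with open chains, methyl and ethyl; the result adds cyclopropyl, with one more heavy atom than ethyl and a three-membered non-aromatic ring of carbon only, and still no pair among the three compounds separates beyond the scatter, so neither going from ethyl to cyclopropyl nor closing a ring shows any effect on the read-out here. No supporting measurement bears on this result, so nothing can be said about what lies behind it.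

The compounds shown leave open whether this flat picture holds for a longer chain, a cyclohexyl ring or a chain ending in an amine or a carboxylic acid on the same nitrogen. They also leave open whether any change elsewhere on the shared core, such as a urea in place of the thiourea, would move the number beyond the scatter.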